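Dimethylamino for Ethylamino on a Second Core

The compounds below may be only part of what the source reports. "The series", "measured", "known", "first", "only" and "open" are said of these compounds alone.

Compound 1, `CCNCC(=O)Nc1cc(OC)ccc1C(=O)c1ccc(OC)c2c1C=CC(C)(C)O2`: 4270 nM
Compound 2, `COc1ccc(C(=O)c2ccc(OC)c3c2C=CC(C)(C)O3)c(NC(=O)CN(C)C)c1`: 3620 nM
Compound 3, `C=C(c1ccc(OC)cc1NC(=O)CNCC)c1ccc(OC)c2c1OC(C)(C)C=C2`: 1090 nM

All three values come from a functional assay on HeLa cells (Homo sapiens) for antiproliferative activity, read by MTT assay, with a stated time of 48 h; on this read-out higher numbers stand for weaker inhibition and lower numbers for stronger inhibition. Compound 1 and compound 2 share one core and differ in a single place: dimethylamino in place of ethylamino on a saturated chain carbon bound to a carbonyl carbon. That change produced a 1.2-fold lower number from compound 1 to compound 2 (0.07 log units; within the scatter), so on this core the two amines are indistinguishable in this assay. Compound 3 carries a different core; how the two cores differ is not broken down here. Compound 3 gives the lowest number of the three in this assay, its nearest neighbour being compound 2.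

Compound 4, `C=C(c1ccc(OC)cc1NC(=O)CN(C)C)c1ccc(OC)c2c1OC(C)(C)C=C2`, has not yet been measured. It relates to compound 3 exactly as compound 2 relates to compound 1: dimethylamino in place of ethylamino on a saturated chain carbon bound to a carbonyl carbon. The change itself is the same in both pairs; only the core on which it sits is different. Because a 1.2-fold lower number from compound 1 to compound 2 (0.07 log units; within the scatter) lay within the scatter, the expectation for the corresponding step on the core of compound 3 is equally small, and compound 4 is estimated at a 1.2-fold lower number from compound 3 to compound 4 (0.08 log units; within the scatter). On that basis compound 4 is expected to give about 900 nM in this assay, with a likely range from 400 nM to 2000 nM. The measured value will show whether the indifference of the first core to this swap carries over to the second.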

Compound 4, half-maximal inhibitory concentration: 900 nM
The estimate for compound 4 equals the measured number at the digits printed, within the range that was stated.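

In this assay, placing dimethylamino where ethylamino stood on the second core gave a 1.2-fold lower number from compound 3 to compound 4 (0.08 log units; within the scatter), so the two amines cannot be told apart on this core either. Set side by side, the steps on the two cores do not differ: the same change on two cores in this assay, a 1.2-fold lower number (0.07 log units; within the scatter) from compound 1 to compound 2 and a 1.2-fold lower number (0.08 log units; within the scatter) from compound 3 to compound 4, 1.0-fold (0.01 log units) apart, within the scatter of two such steps. This shows that, in this small series, the change carries from one core to the other with the same outcome, namely no difference that can be separated from the scatter; it does not show that the same would hold on any further core, and since neither step moved the number beyond the scatter, these two pairs cannot tell whether a change with a larger effect would carry across in the same way.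

The compounds shown leave open what other groups would do on the same saturated chain carbon bound to a carbonyl carbon, for instance a primary amine, diethylamino, or a cyclic amine such as pyrrolidine or morpholine. They also leave open whether a longer chain between the carbonyl and the amine would give the same result on both cores, or whether the two cores would then part ways.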